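A few compounds are considered here, and "the series" means these few. Any claim that something is new, unique, unknown or untested is made for them only; others in the source may bear on it.

Within the data shown here, compound 1 `O=C1c2ccccc2N(COCc2ccccc2)S(=O)(=O)N1Cc1ccccc1` is the one compound of this pair with a number in a functional assay on CCRF-CEM cells (Homo sapiens) for cytotoxicity; a higher number here means that more compound is tolerated, a lower number that less compound is tolerated: compound 1 gives 25 ug/mL. Compound 2 `O=C1NS(=O)(=O)N(COCc2ccccc2)c2ccccc21` gives > 200 ug/mL in this assay, which is a limit of the assay rather than a number. Among the measured compounds shown here, the step of an at least 8.0-fold higher number from compound 1 to compound 2 (0.90 log units; beyond the scatter) is the only measured step, and it ends at the limit of > 200 ug/mL in this assay, at which 1 of the 2 values shown sits.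

Compound 3 `C#CCOCN1c2ccccc2C(=O)N(Cc2ccccc2)S1(=O)=O` differs from compound 1 at another place: ethynyl in place of phenyl on a saturated chain carbon bound to an oxygen on a saturated carbon. For the measured compounds named here, the measured step concerns the amide-type nitrogen in the ring and not the chain on the other nitrogen, so no measured step bears directly on the change from compound 1 to compound 3. For compound 3 the expectation therefore rests on compound 1 alone, and an expected step of a 1.4-fold higher number from compound 1 to compound 3 (0.15 log units; within the scatter) in this assay is taken as lying within the scatter. Compound 3 is estimated at 35 ug/mL in this assay, with a range from 10 ug/mL to 150 ug/mL.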

Compound 3, half-maximal cytotoxic concentration: 23 ug/mL
Compound 3: the middle estimate sits 1.5-fold (0.18 log units) above what was measured; measured number inside the range.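

Replacing phenyl with ethynyl on a saturated chain carbon bound to an oxygen on a saturated carbon gives a 1.1-fold lower number from compound 1 to compound 3 (0.04 log units; within the scatter) in this assay. Among these compounds, this is the first reading at this place, and for this one pair it shows that the phenyl ring, with its 6 heavy atoms, can give way to ethynyl, with its 2 heavy atoms, without a change beyond the scatter, whereas the change on the amide-type nitrogen in the ring gave an at least 8.0-fold higher number from compound 1 to compound 2 (0.90 log units; beyond the scatter) as its step. No measurement shown offers a cause for the result at this place.

As far as these compounds go, what remains open is whether a longer chain, an amine or a carboxylic acid at this place would also stay within the scatter of compound 1. Also open, from the compounds shown here alone, is whether ethynyl behaves the same way with hydrogen in place of benzyl on the amide-type nitrogen.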